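This account rests on a few compounds, and the source may have more. Where it says the series, first, only, none or still open, it means among the compounds named here.

The measured compounds and their values:

Compound 1, `Cc1[nH]n(-c2nc3c(C)cccc3[nH]2)c(=O)c1Cc1ccccc1`, gives 5900 nM in an assay on isolated protein for inhibition of alpha-ketoglutarate-dependent dioxygenase alkB homolog 3 (Homo sapiens), read by polymerase chain reaction, with a stated time of 1 h; on this read-out higher numbers stand for weaker inhibition and lower numbers for stronger inhibition.
Compound 2, `Cc1ccc2[nH]c(-n3[nH]c(C)c(Cc4ccccc4)c3=O)nc2c1`, gives 670 nM in this assay.
Compound 3, `Cc1ccc2[nH]c(-n3[nH]c(C)c(C)c3=O)nc2c1`, gives 2600 nM in this assay.

Compound 1 and compound 2 share the same atoms joined differently; the difference between the two cores is not broken down here, and their values alone show that compound 1 stands highest of the three, with compound 2 the furthest from it and compound 3 the nearest. On the core of compound 2, the change hydrogen in place of phenyl on a saturated chain carbon bound to an aromatic carbon was made, and the step it produced was a 3.9-fold higher number from compound 2 to compound 3 (0.59 log units; beyond the scatter).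

Compound 4, `Cc1[nH]n(-c2nc3c(C)cccc3[nH]2)c(=O)c1C`, is not yet measured. It is related to compound 1 by hydrogen in place of phenyl on a saturated chain carbon bound to an aromatic carbon, which is the same change that separates compound 2 from compound 3, made at the same place in the words given above. The expectation for compound 4 therefore rests on that single measured example: because the earlier step was a 3.9-fold higher number from compound 2 to compound 3 (0.59 log units; beyond the scatter), the step from compound 1 to compound 4 is estimated to be a 3.9-fold higher number from compound 1 to compound 4 (0.59 log units; beyond the scatter). On this basis compound 4 is expected to give about 23000 nM in this assay, with a plausible span from 10000 nM to 55000 nM. Since compound 1 already stands highest of the measured set, a number of this size for compound 4 could approach the range in which the assay reports only a limit rather than a value.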

Compound 4, half-maximal inhibitory concentration: > 10000 nM
Compound 4: no number, only a limit (the forecaster's own chance of this, stated with the estimate: 20%); the middle value lies beyond the limit too.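

In this assay compound 4 gives > 10000 nM, which is a limit of the assay and not a number. Going from benzyl to methyl on the core of compound 1 gives an at least 1.6-fold higher number from compound 1 to compound 4 (0.22 log units; that floor lies within the scatter), so the result is compatible with the rise seen on the other core, but the floor by itself does not establish a rise beyond the scatter, and the true size of the step on this core remains unknown. The change therefore has one measured size and one lower bound, and the comparison between the two cores goes only this far: the same change on two cores in this assay, a 3.9-fold higher number (0.59 log units; beyond the scatter) from compound 2 to compound 3 and an at least 1.6-fold higher number (0.22 log units; that floor lies within the scatter) from compound 1 to compound 4; the limit leaves it open whether they differ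

The compounds shown leave open how the value would respond to other groups at this place on a saturated chain carbon bound to an aromatic carbon, such as a longer chain, an amine or a carboxylic acid, since only benzyl and methyl appear there. They also leave open whether a group other than benzyl could bring the core of compound 1 closer to compound 2, and a true number for compound 4 would be needed before the two steps could be compared directly.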